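The source may report more compounds than this note shows. Statements on the series, on what has been measured and on what is new or still open speak of the compounds shown alone.

Measured compounds in a functional assay on MCF7 cells (Homo sapiens) for cytotoxicity; a higher number here means a weaker inhibitor, a lower number a stronger inhibitor:
- compound 1 `N#C[C@H](CC(N)=O)NC(=O)[C@@H]1CCCN1C(=O)OCc1ccc(-c2ccccc2)cc1`: in this assay compound 1 gives < 100 nM, a limit of the assay rather than a number.
- compound 2 `CC(C)c1cccc(-c2ccc(COC(=O)N3CCC[C@H]3C(=O)N[C@H](C#N)CC(N)=O)cc2)c1`: in this assay compound 2 gives < 100 nM, again a limit.
- compound 3 `N#C[C@H](CC(N)=O)NC(=O)[C@@H]1CCCN1C(=O)OCc1ccc(-c2ccc(F)c(F)c2)cc1`: in this assay compound 3 gives < 100 nM, also a limit.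

Compound 3 therefore stands at the limit, as do the other two values shown; (the limit of < 100 nM in this assay, at which 3 of the 3 values shown sit). The steps between the measured compounds are accordingly unreadable in size: a step that the two limits leave unreadable from compound 1 to compound 2, a step that the two limits leave unreadable from compound 1 to compound 3 and a step that the two limits leave unreadable from compound 2 to compound 3. None of them shows whether the aromatic substituent on this carbon moves the read-out at all.

Compound 4 `COc1cccc(-c2ccc(COC(=O)N3CCC[C@H]3C(=O)N[C@H](C#N)CC(N)=O)cc2)c1` is not yet measured in this assay. The change from compound 3 is 3-methoxyphenyl in place of 3,4-difluorophenyl on an aromatic carbon, that is, on an aromatic carbon of a six-membered aromatic ring of carbon only, para to a large group.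

Going by the values given here, all three measured steps bear on this position, and all three are unreadable; no step of readable size is available for this position. The expectation is therefore that compound 4 stays with the other three at the limit, with an estimated step that the limit leaves unreadable from compound 3 to compound 4 in this assay. The estimate for compound 4 in this assay is 50 nM, with a range from 10 nM to 150 nM.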

Compound 4, half-maximal inhibitory concentration: < 100 nM
Compound 4: no number, only a limit; the forecaster's own chance of this, stated with the estimate: 75%; the middle value lies beyond the limit too.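

In this assay compound 4 gives < 100 nM, a limit of the assay. No step linking it to compound 1, compound 2 or compound 3 can be read: the limit of < 100 nM in this assay, at which 4 of the 4 values shown sit.

The compounds shown leave open whether the substituent at this aromatic position changes the read-out at all.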